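The source may hold more compounds than are shown below. What is called first, only, known or untested is meant among the compounds shown, and "the series" means these compounds.

For the measured compounds named here, compound 3 `O=C(NOCc1ccccc1F)c1cn(-c2ccccc2)nc1-c1ccc(Cl)cc1` is one of three compounds measured in a functional assay on A549 cells (Homo sapiens) for antiproliferative activity, read by MTT assay, with a stated time of 48 h, in the presence of a further agent that is not named here (a lower number here means a stronger inhibitor of growth, a higher number a weaker inhibitor of growth), where compound 3 gives 12100 nM. Compound 2 `O=C(NOCc1ccccc1)c1cn(-c2ccccc2)nc1-c1ccc(Cl)cc1` gives 13000 nM, and compound 1 `O=C(NOCc1ccccc1Cl)c1cn(-c2ccccc2)nc1-c1ccccc1` gives 10300 nM. The number for compound 3 sits among the other two, and all three lie within the usual scatter of one another. Going by the values given here, the single measured step that reaches compound 3 is a 1.1-fold lower number from compound 2 to compound 3 (0.03 log units; within the scatter), a swap of hydrogen for fluoro. Compound 4 `O=C(NOCc1ccccc1Cl)c1cn(-c2ccccc2)nc1-c1ccc(Cl)cc1` differs from compound 3 by chloro in place of fluoro on an aromatic carbon. Since the earlier change at this same place stayed within the scatter, the expected step in this assay is a 1.1-fold lower number from compound 3 to compound 4 (0.04 log units; within the scatter), no shift beyond the scatter. The estimate for compound 4 is 11000 nM, with a range from 5500 nM to 22000 nM.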

Compound 4, concentration for 50% growth inhibition: 15500 nM
Beside the measured number, compound 4's estimate is 1.4-fold (0.15 log units) below it; low and high end bracket the measured number.
By their numbers in this assay, from the lowest: compounds 1, 3, 2 and 4 (each within the scatter of the next).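

In this assay, chloro at this place, on an aromatic carbon ortho to a large group, stays within the scatter of fluoro (a 1.3-fold higher number from compound 3 to compound 4 (0.11 log units; within the scatter)) and of hydrogen (a 1.2-fold higher number from compound 2 to compound 4 (0.08 log units; within the scatter)), so these three substituents are not told apart here. Chloro in place of hydrogen at a second place, on the shared core, also stays within the scatter (a 1.5-fold higher number from compound 1 to compound 4 (0.18 log units; within the scatter)). No measurement available here offers an explanation for these steps. From the compounds shown here alone, whether a methoxy group, an amine or a carboxylic acid at the first place would give a step beyond the scatter remains open.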